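The compounds below may be only part of what the source reports. "The series", "measured", "known", "first", "only" and "open" are said of these compounds alone.

Compound 1 `COc1nc(-c2cc3ccccc3o2)cc(-c2ccc3ccccc3c2)c1C#N`: 320000 nM
Compound 2 `CCOc1nc(-c2cc3ccccc3o2)cc(-c2ccc3ccccc3c2)c1C#N`: 423000 nM
Compound 3 `COc1nc(-c2cc3ccccc3o2)cc(-c2ccc(Br)cc2)c1C#N`: 298000 nM

All three were tested in a functional assay on aorta (strain Wistar) for inhibition, with Thoracic aorta (Rattus norvegicus) as the target; on this read-out lower numbers stand for stronger inhibition and higher numbers for weaker inhibition. Compound 2 gives the highest number of the three, yet its gaps to compound 1 and to compound 3 both lie within the scatter, so the three compounds cannot be ranked against one another. Among the measured compounds shown here, the one single-point step among them, a 1.3-fold higher number from compound 1 to compound 2 (0.12 log units; within the scatter), also stays within the scatter.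

Compound 4 `CCOc1nc(-c2cc3ccccc3o2)cc(-c2ccc(OC)cc2)c1C#N` is built from compound 2 by 4-methoxyphenyl in place of naphthalen-2-yl on an aromatic carbon. For the measured compounds named here, no measured step covers this exchange directly. The nearest hint comes from compound 1, with naphthalen-2-yl, which gives 320000 nM, and compound 3, with 4-bromophenyl, which gives 298000 nM: two numbers that sit close together. Nothing in these data therefore points to a step beyond the scatter when the naphthalen-2-yl group of compound 2 is replaced. Compound 4 is accordingly expected to land near compound 2, with an estimated step of a 1.1-fold lower number from compound 2 to compound 4 (0.02 log units; within the scatter). The estimate for compound 4 in this assay is 400000 nM, within a range from 150000 nM to 1000000 nM.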

Compound 4, half-maximal inhibitory concentration: 204000 nM
For compound 4 the middle estimate is 2.0-fold (0.29 log units) above the measured one, and the stated range covers the measured number.
By their numbers in this assay, from the lowest: compounds 4, 3, 1 and 2 (each within the scatter of the next, the first and the last beyond it).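

In this assay, among the compounds shown here, replacing naphthalen-2-yl with 4-methoxyphenyl on the aromatic carbon opposite the ring nitrogen gives a 2.1-fold lower number from compound 2 to compound 4 (0.32 log units; beyond the scatter), the first step here to pass beyond the scatter, although only modestly. The earlier single-point change, at the ethoxy group rather than at this position, gave a 1.3-fold higher number from compound 1 to compound 2 (0.12 log units; within the scatter) and so showed no measurable effect; the number therefore does respond to the group at this carbon, at least with ethoxy on the shared core. The exchange removes one six-membered aromatic ring and brings in an oxygen that counts as a hydrogen-bond acceptor, but no supporting measurement bears on the result, and these data cannot separate the two differences.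

The compounds shown leave open whether the same exchange would give a step of similar size with methoxy in place of ethoxy on the core. They also leave open whether an amine or a carboxylic acid in place of the methoxy group of 4-methoxyphenyl, or a longer chain in place of ethoxy, would move the number further in either direction.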